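The compounds below may be only part of what the source reports. "The series", "measured", "known", "first", "only" and "open" are said of these compounds alone.

Of the compounds shown here, two of this small set have so far been tested in an assay on HEK293 cells for inhibition of sodium channel protein type 3 subunit alpha (Homo sapiens), read by electrophysiology, with a stated time of 3.5 min; on this read-out higher numbers stand for weaker inhibition and lower numbers for stronger inhibition. Compound 1 `N#Cc1ccccc1Oc1ccc([C@H]2CC[C@@H](C(N)=O)N2)cc1` gave no number in this assay, only a limit, > 100000 nM. Compound 2 `N#Cc1ccccc1COc1ccc([C@H]2CC[C@@H](C(N)=O)N2)cc1` likewise gave only a limit in this assay, > 63000 nM. On the numbers shown, compound 2 therefore stands at a limit, and since compound 1 also stands at a limit, no step between the two can be sized. Compound 3 `NC(=O)[C@@H]1CC[C@H](c2ccc(OCc3ccccc3)cc2)N1` has not yet been measured. It differs from compound 2 by hydrogen in place of cyano on an aromatic carbon. Among the compounds with values here, with no measured step to lean on and compound 2 resting at a limit, the step that the limit leaves unreadable from compound 2 to compound 3 is expected to stay within the usual scatter, in no particular direction. Compound 3 is accordingly estimated at 80000 nM in this assay, within a range from 30000 nM to 200000 nM, and most likely to be reported again only as a limit.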

Compound 3, half-maximal inhibitory concentration: > 63000 nM
Compound 3 gave a limit, no number (the forecaster's own chance of this, stated with the estimate: 80%); the middle value lies beyond the limit too.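

Within the data shown here, compound 2 and compound 3 both stand only as limits in this assay, so no step between them can be read. The compounds shown leave open whether the change from 2-cyanophenyl to phenyl alters inhibition, and what number any of them would give in this assay.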